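The compounds below may be only part of what the source reports. "The series", "measured", "known", "first", "only" and "open" are said of these compounds alone.

Among the compounds with values here, compound 1 `CC(C)=CCC[C@]1(C)/C=C/[C@@H](OC(=O)C=C(C)C)[C@](C)(O)/C=C/C(=O)/C(CN2CCCC2)=C\C1` is the only member of this set with a measured number: in a functional assay on SW480 cells (Homo sapiens) for antiproliferative activity, read by MTT assay, with a stated time of 48 h (a lower number here means a stronger inhibitor, a higher number a weaker inhibitor), compound 1 gives 310 nM. Compound 2 `CC(C)=CCC[C@]1(C)/C=C/[C@@H](OC(=O)C=C(C)C)[C@](C)(O)/C=C/[C@H](O)/C(CO)=C\C1` reaches only a limit of the assay, > 40000 nM, so the two values cannot be compared as numbers; one of the two values shown sits at the limit of > 40000 nM in this assay, at which 1 of the 2 values shown sits. Compound 3 `CCN(CC)C(=O)/C1=C/C[C@](C)(CCC=C(C)C)/C=C/[C@@H](OC(=O)C=C(C)C)[C@](C)(O)/C=C/C1=O` differs from compound 1 in a single way: diethylcarbamoyl in place of (pyrrolidin-1-yl)methyl on a double-bonded ring carbon. Within the data shown here, no step between measured compounds is available to calibrate this change, so a moderate loss of potency is expected, a 4.8-fold higher number from compound 1 to compound 3 (0.68 log units; beyond the scatter). Compound 3 is therefore estimated at 1500 nM, with a likely range from 400 nM to 8000 nM.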

Compound 3, half-maximal inhibitory concentration: 11700 nM
Compound 3: the middle estimate sits 7.8-fold (0.89 log units) below what was measured; the whole stated range lies below it.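

In this assay, replacing (pyrrolidin-1-yl)methyl with diethylcarbamoyl on this double-bonded ring carbon gives a 38-fold higher number from compound 1 to compound 3 (1.58 log units; beyond the scatter), so the reading depends strongly on the group at this place. The change combines two differences, the loss of the five-membered ring and the entry of a carbonyl, and this one pair cannot separate them. Nothing shown gives a cause for this step. Where a diethylaminomethyl group or a pyrrolidin-1-ylcarbonyl group would fall relative to compound 1 and compound 3 remains open. As far as these compounds go, the effect of a primary amine or a carboxylic acid at this place also remains open.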